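The source may report more compounds than this note shows. Statements on the series, on what has been measured and on what is new or still open speak of the compounds shown alone.

In an ADME assay on WI-38 cells (Homo sapiens) for cytotoxicity, read by MTT assay, with a stated time of 72 h (a lower number here means a stronger inhibitor, a higher number a weaker inhibitor), two compounds have been measured so far. Compound 1 `C#Cc1cccc(NC(=O)CCc2cccc3c2B(O)OC3)c1` gives > 100000 nM, which is a limit of the assay and not a number. Going by the values given here, compound 2 `CC(=O)c1ccc(-c2cccc(NC(=O)CCc3ccccc3)c2)cc1` gives 13000 nM, the only true number available, so it serves as the reference point here. Compound 3 `CC(=O)c1ccc(-c2cccc(NC(=O)CCc3cccc4c3C(O)OC4)c2)cc1` keeps most of compound 2 but changes one end of it: a group of 10 heavy atoms (8 carbon, 2 oxygen; one five-membered non-aromatic ring with 1 hetero atom, one six-membered aromatic ring of carbon only) in place of a group of 6 heavy atoms (6 carbon; one six-membered aromatic ring of carbon only), on a saturated chain carbon, two bonds along the chain from a carbonyl carbon. The swap takes place on a saturated chain carbon, two bonds along the chain from a carbonyl carbon. Among the compounds with values here, no measured pair shows what such a swap does in this assay, so any forecast rests on little evidence. A modest shift towards weaker inhibition is expected, with the estimated change being a 1.5-fold higher number from compound 2 to compound 3 (0.19 log units; within the scatter). For compound 3, the expected value is 20000 nM, with an estimated range of 7000 nM to 60000 nM.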

Compound 3, half-maximal inhibitory concentration: > 100000 nM
Compound 3 ended at the assay's limit (the forecaster's own chance of this, stated with the estimate: 15%); middle value at least 5.0-fold (0.69 log units) from the limit.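

In this assay, going by these compounds alone, the step at this position is the first measured one: the group of 10 heavy atoms, with its five-membered non-aromatic ring, replaces phenyl on the saturated chain carbon and gives an at least 7.6-fold higher number from compound 2 to compound 3 (0.88 log units; beyond the scatter). As far as these compounds go, the value of compound 3 is a limit and not a number, so the step fixes only a minimum size for the change, and its true size stays unknown. No finer reading of this swap is possible, as the values shown crowd at the top of the scale: the limit of > 100000 nM in this assay, at which 2 of the 3 values shown sit.

The compounds shown leave open which part of the entering group goes with the change, the five-membered non-aromatic ring or the six-membered aromatic ring. They also leave open how a smaller group on that saturated chain carbon, such as a methyl or an amine, would read.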